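The source may report more compounds than this note shows. Statements on the series, on what has been measured and on what is new or still open speak of the compounds shown alone.

In an ADME assay for permeability, using PAMPA, with a stated time of 30 min, at pH 7.4 (a higher number here means that the compound crosses the layer faster, a lower number that the compound crosses the layer more slowly), compound 1 `COc1ccc(F)cc1CNCCCNc1ccnc2cc(C3CCCCC3)ccc12` gives 23 10^-6 cm/s. Compound 2 `Fc1ccc(Oc2ccc3c(NCCCNCc4ccco4)ccnc3c2)cc1` gives 317 10^-6 cm/s in this assay, so compound 1 holds the lower of the two numbers recorded so far, and the gap to compound 2 lies beyond the scatter. Compound 3 `CCC(CC)c1ccc2c(NCCCNCc3cc(F)ccc3OC)ccnc2c1` is not yet measured in this assay. It differs from compound 1 in one place: pentan-3-yl in place of cyclohexyl on an aromatic carbon. Among the measured compounds shown here, no measured pair shows this change on its own; the expected step of a 1.1-fold higher number from compound 1 to compound 3 (0.04 log units; within the scatter) is no larger than the scatter, in either direction. Compound 3 is therefore estimated at 25 10^-6 cm/s, within 10 10^-6 cm/s to 60 10^-6 cm/s.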

Compound 3, apparent permeability: 23 10^-6 cm/s
Estimate against measurement, compound 3: 1.1-fold (0.04 log units) above; the range from low to high includes it.
By their numbers in this assay, from the lowest: compounds 1 and 3 (each within the scatter of the next); then compound 2.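

Pentan-3-yl in place of cyclohexyl on this aromatic carbon gives no change at the digits printed from compound 1 to compound 3 (within the scatter) in this assay. Among the compounds shown here, this is the first single-place reading at this position, and it shows that, for this pair, the ring of carbon only can be replaced by an open branched group without a step beyond the scatter. No measurement on hand explains this result.

The compounds shown leave open whether this holds for groups other than carbon-only ones, since only groups without hydrogen-bond donors or acceptors appear at this position. An amine or a carboxylic acid on this aromatic carbon, or a longer straight chain, remains an open case.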